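This account rests on a few compounds, and the source may have more. Where it says the series, first, only, none or still open, it means among the compounds named here.

Measured compounds:
- compound 1 `Cc1cc(CC(C)C(=O)N2CCN(c3ccc(C(F)(F)F)cc3[C@@H](N)CC(C)C)CC2)ccc1Cl`: 71 nM
- compound 2 `CC(C)C[C@H](N)c1cc(C(F)(F)F)ccc1N1CCN(C(=O)C(C)Cc2ccc(Cl)cc2)CC1`: 47 nM
- compound 3 `CC(C)C[C@H](N)c1cc(C(F)(F)F)ccc1N1CCN(C(=O)C(C)Cc2ccc(Cl)c(Cl)c2)CC1`: 120 nM; 1600 nM (2 entries)

In an assay on HEK293 cells for displacement of a labelled ligand from Melanocortin receptor 4 (Homo sapiens) (on this read-out lower numbers stand for stronger inhibition and higher numbers for weaker inhibition), compound 2 gives the lowest of the two single numbers; the nearest is compound 1, and the step of a 1.5-fold lower number from compound 1 to compound 2 (0.18 log units; within the scatter) stays within the scatter, so no order between these two is claimed. Compound 3 has no single number: the several entries of compound 3 in this assay, (the several entries of compound 3 in this assay, 120 nM; 1600 nM (2 entries)), spread far apart, so compound 3 gives no usable anchor.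

Compound 4 `COc1ccc(CC(C)C(=O)N2CCN(c3ccc(C(F)(F)F)cc3[C@@H](N)CC(C)C)CC2)cc1F` is the next member; it differs from compound 2 by 3-fluoro-4-methoxyphenyl in place of 4-chlorophenyl on a saturated chain carbon, two bonds along the chain from a carbonyl carbon. Among the measured compounds shown here, the only measured step, from compound 1 to compound 2, concerns a methyl on an aromatic carbon and is within the scatter, so it gives little guidance on an exchange of the whole aryl group on a saturated chain carbon two bonds along the chain from a carbonyl carbon. The wide spread of compound 3 adds uncertainty rather than direction.

The estimated step is therefore small and uncertain, a 2.6-fold higher number from compound 2 to compound 4 (0.41 log units; beyond the scatter), and compound 4 is expected at 120 nM with a range from 35 nM to 450 nM.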

Compound 4, inhibition constant: 200 nM
The estimate for compound 4 lay 1.7-fold (0.22 log units) below the measured number; the range from low to high includes it.
By their numbers in this assay, from the lowest: compounds 2 and 1 (each within the scatter of the next); then compound 4.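

In this assay, among the compounds shown here, the aryl group on the saturated chain carbon, two bonds along the chain from a carbonyl carbon, gives the first steps beyond the scatter: 3-fluoro-4-methoxyphenyl in place of 4-chlorophenyl gives a 4.3-fold higher number from compound 2 to compound 4 (0.63 log units; beyond the scatter), and in place of 4-chloro-3-methylphenyl it gives a 2.8-fold higher number from compound 1 to compound 4 (0.45 log units; beyond the scatter). Both steps are modest and run the same way, whereas the methyl exchange on the aromatic carbon stayed within the scatter. The exchange removes chlorine and brings in methoxy and fluorine together, so neither step can be assigned to one of these groups.

From the compounds shown here alone, how an amine or a carboxylic acid on the aryl group, or a longer chain leading to it, would read remains open. The effect of a second chlorine also remains open, since compound 3 gives no single number: the several entries of compound 3 in this assay, 120 nM; 1600 nM (2 entries)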